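A few compounds are considered here, and "the series" means these few. Any claim that something is new, unique, unknown or untested is made for them only; others in the source may bear on it.

Compound 1 `Oc1ccc(-c2cc(-c3ccccc3O)cc(-c3cccc(O)c3)n2)cc1` gives 0% in an assay on isolated protein for inhibition of DNA topoisomerase 1 (Homo sapiens), with a stated time of 30 min, tested at 100 uM; on this read-out higher numbers stand for more inhibition at the one concentration tested (going by the name of the read-out) and lower numbers for less inhibition. Compound 2 `Oc1cccc(-c2cc(-c3ccccc3O)nc(-c3ccccc3O)c2)c1` gives 4.9% in this assay.

Compound 2 stands at the upper of the two numbers, but its value and that of compound 1 lie within the scatter of each other, so the two cannot be told apart. Compound 3 `Oc1cccc(-c2cc(-c3cccc(O)c3)nc(-c3ccccc3O)c2)c1` has not been measured in this assay. Compound 3 differs from compound 2 by 3-hydroxyphenyl in place of 2-hydroxyphenyl on an aromatic carbon. With both measured compounds near zero, the step of a number 1.9 percentage points lower from compound 2 to compound 3 (within the scatter) is expected to stay within the scatter, with no clear direction. Compound 3 is estimated to give 3% in this assay, within 0% to 15%.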

Compound 3, a percentage reported as inhibition, at one concentration (the size of the read-out at that concentration, not a potency): 1.9%
Compound 3: the middle estimate sits 1.1 percentage points above what was measured, within the range that was stated.
By their numbers in this assay, from the lowest: compounds 1, 3 and 2 (each within the scatter of the next).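

In this assay, the swap of 2-hydroxyphenyl for 3-hydroxyphenyl on the aromatic carbon next to the ring nitrogen gives a number 3 percentage points lower from compound 2 to compound 3 (within the scatter), so the two hydroxyphenyl groups cannot be told apart at this position. Moving the hydroxyl around this ring thus gives no measurable handle on inhibition here. Nothing available bears on why this is so.

The compounds shown leave open whether this position responds to anything other than a hydroxyphenyl group. An amine or a carboxylic acid on that ring, for example, could give a value that stands clear of the scatter.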